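Methyl in Place of Chloro: What to Expect for Permeability

The compounds below may be only part of what the source reports. "The series", "measured", "known", "first", "only" and "open" are said of these compounds alone.

Going by the values given here, compound 2 `Cn1c(COc2cccc(C(=O)O)c2)nc2ccc(Oc3ncc(Cl)cc3Cl)cc21` gives 16.1 10^-6 cm/s in an ADME assay for permeability, using PAMPA, with a stated time of 4 h (on this read-out lower numbers stand for lower permeability and higher numbers for higher permeability), the highest of the two numbers so far; compound 1 `Cn1c(COc2cccc(C(=O)O)c2)nc2ccc(Oc3cccc(Cl)n3)cc21` gives 7.6 10^-6 cm/s in this assay. Among the compounds with values here, the one measured step, a 2.1-fold higher number from compound 1 to compound 2 (0.33 log units; beyond the scatter), exchanged the whole group on the oxygen rather than a single substituent. Compound 3 `Cc1cc(Cl)cnc1Oc1ccc2nc(COc3cccc(C(=O)O)c3)n(C)c2c1` differs from compound 2 by methyl in place of chloro on an aromatic carbon. Within the data shown here, no measured step matches this swap, so the expectation rests on the two groups having the same count of heavy atoms and no donors or acceptors. Compound 3 is expected to change little, a 1.2-fold lower number from compound 2 to compound 3 (0.06 log units; within the scatter), with an estimated 14 10^-6 cm/s and a range from 7 10^-6 cm/s to 28 10^-6 cm/s.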

Compound 3, apparent permeability in the ADME assay: 13.7 10^-6 cm/s
Estimate against measurement, compound 3: 1.0-fold (0.01 log units) above; the measured number falls inside the stated range.
By their numbers in the ADME assay, from the lowest: compounds 1, 3 and 2 (each within the scatter of the next, the first and the last beyond it).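

On this aromatic carbon, the swap of chloro for methyl gives no readable change in the ADME assay, with a 1.2-fold lower number from compound 2 to compound 3 (0.07 log units; within the scatter). Compound 3 also stays close to the earlier compound 1, with a 1.8-fold higher number from compound 1 to compound 3 (0.26 log units; within the scatter), whereas compound 2 stood clearly apart from it. The same swap does show in a physicochemical assay for solubility, read by HPLC, measured as thermodynamic solubility, with a stated time of 4 h, at pH 6.8 (on this read-out higher numbers stand for higher solubility and lower numbers for lower solubility), where compound 2 gives 9.9 ug/mL and compound 3 gives 3.9 ug/mL: the measured solubility of compound 2, 9.9 ug/mL, and of compound 3, 3.9 ug/mL, a 2.5-fold lower number (0.40 log units; beyond the scatter).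

This is a single pair of compounds, so it sets no general rule for the swap. On these data alone, how an amine or a methoxy group on this carbon would read in the ADME assay and in the physicochemical assay remains open.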